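From Fluoro to Butyl: An Expected Loss of Potency

The source may hold more compounds than are shown below. What is called first, only, known or untested is meant among the compounds shown, and "the series" means these compounds.

Of the compounds shown here, three sharing one core have been measured in a functional assay on HEK293 cells for activation of melanin-concentrating hormone receptor 1 (Homo sapiens), read by inositol phosphate accumulation; a higher number here means that more compound is needed for the effect, a lower number that less compound is needed. Compound 1 `CCCc1cc(N)c2cc(NC(=O)/C=C/c3ccc(C(C)(C)C)cc3)ccc2n1` gives 910 nM. Compound 2 `CCCc1cc(NC2CCC2)c2cc(NC(=O)/C=C/c3ccc(C(F)(F)F)cc3)ccc2n1` gives 270 nM. Compound 3 `CCCc1cc(N)c2cc(NC(=O)/C=C/c3ccc(F)cc3)ccc2n1` gives 200 nM. Among these, compound 3 lies at the low end: compound 1 lies beyond the scatter from it, while compound 2 lies within the scatter of it, so no order between compounds 2 and 3 can be claimed. Among the compounds with values here, the only single-point step available is a 4.6-fold lower number from compound 1 to compound 3 (0.66 log units; beyond the scatter), a swap at the same aromatic carbon that is in question now.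

Compound 4 `CCCCc1ccc(/C=C/C(=O)Nc2ccc3nc(CCC)cc(N)c3c2)cc1` differs from compound 3 by butyl in place of fluoro on an aromatic carbon. This runs the earlier step backwards in spirit: a single halogen gives way to an alkyl chain, much as compound 1 carries a larger tert-butyl group where compound 3 has fluoro. Because a 4.6-fold lower number from compound 1 to compound 3 (0.66 log units; beyond the scatter) lowered the number beyond the scatter, the expectation for compound 4 is that the number rises again, though a straight butyl chain is not identical to tert-butyl and need not track it exactly. Compound 4 is therefore expected to give 600 nM, within a range of 200 nM to 1800 nM, an expected step of a 3.0-fold higher number from compound 3 to compound 4 (0.48 log units; beyond the scatter).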

Compound 4, half-maximal effective concentration: 740 nM
Beside the measured number, compound 4's estimate is 1.2-fold (0.09 log units) below it; the range from low to high includes it.
By their numbers in this assay, from the lowest: compounds 3 and 2 (each within the scatter of the next); then compounds 4 and 1 (each within the scatter of the next).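

The rise is not tied to branching in the alkyl group: a 3.7-fold higher number from compound 3 to compound 4 (0.57 log units; beyond the scatter) shows that a straight butyl chain at this aromatic carbon also gives a number beyond the scatter from that of the fluoro compound, the same direction as the earlier move between fluoro and tert-butyl. The two alkyl groups cannot be told apart here, since a 1.2-fold lower number from compound 1 to compound 4 (0.09 log units; within the scatter) leaves compound 1 and compound 4 within the scatter of each other, so among the three compounds that differ only at this carbon, both alkyl groups stand apart from fluoro. Nothing measured here gives a reason for this difference.

From the compounds shown here alone, it remains open whether a shorter chain such as ethyl, or a methoxy group or an amine at the same carbon, would give a number close to that of the fluoro compound or close to those of the two alkyl compounds. Compound 2 differs from these compounds in two places, so it cannot show whether its trifluoromethyl group alone would follow fluoro or the alkyl groups.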